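Replacing an acetyl group with a cyclopropylcarbonylamino group

The source may report more compounds than this note shows. Statements on the series, on what has been measured and on what is new or still open speak of the compounds shown alone.

Compound 1 `CNC(=O)c1cnc(N2CCN(C3CCN(Cc4ccc(Cl)cc4)CC3)[C@@H](C)C2)c(Cl)c1` gives 32 nM in a functional assay for antagonist activity at C-X-C chemokine receptor type 3 (Homo sapiens); a higher number here means a weaker inhibitor, a lower number a stronger inhibitor.
Compound 2 `C[C@H]1CN(c2ncc(C(=O)NCc3ccc(F)c(F)c3)cc2Cl)CCN1C1CCN(Cc2ccc(Cl)cc2)CC1` gives 6 nM in this assay.
Compound 3 `CC(=O)c1cnc(N2CCN(C3CCN(Cc4ccc(Cl)cc4)CC3)[C@@H](C)C2)c(Cl)c1` gives 520 nM in this assay.

Compound 3 stands at the highest of the three numbers, that is, it is the weakest inhibitor of the three. Its nearest neighbour is compound 1, with a 16-fold higher number from compound 1 to compound 3 (1.21 log units; beyond the scatter), and its furthest is compound 2, with an 87-fold higher number from compound 2 to compound 3 (1.94 log units; beyond the scatter). Both of these steps change the group on the same carbonyl carbon, and both are large.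

Compound 4 `C[C@H]1CN(c2ncc(NC(=O)C3CC3)cc2Cl)CCN1C1CCN(Cc2ccc(Cl)cc2)CC1` is made from compound 3 by a change at the same position: (cyclopropylcarbonyl)amino in place of acetyl on an aromatic carbon. The entering group brings back an amide-type unit with a hydrogen-bond donor and acceptor, which compound 3 lacks and compounds 1 and 2 possess. Going from compound 3 to compound 1 and to compound 2, adding such a unit lowered the number strongly. Among the measured compounds shown here, a step of similar kind, downward, is therefore expected here, though its size is uncertain since the amide is reversed and no measured pair shows that exact change. The expected step is a 10-fold lower number from compound 3 to compound 4 (1.02 log units; beyond the scatter), giving an estimate for compound 4 of 50 nM, within a range from 10 nM to 250 nM.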

Compound 4, half-maximal inhibitory concentration: 20 nM
Compound 4: middle estimate off by 2.5-fold (0.40 log units), on the high side, and the stated range covers the measured number.
By their numbers in this assay, from the lowest: compound 2; then compounds 4 and 1 (each within the scatter of the next); then compound 3.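

In this assay, the amide on this aromatic carbon need not have its carbonyl attached to the ring: the reversed amide in (cyclopropylcarbonyl)amino, in place of acetyl, gives a 26-fold lower number from compound 3 to compound 4 (1.41 log units; beyond the scatter) and so recovers most of what compound 3 lost. Its result matches that of the methylcarbamoyl group, with a 1.6-fold lower number from compound 1 to compound 4 (0.20 log units; within the scatter) showing no real difference between the two. The (3,4-difluorobenzyl)carbamoyl group still keeps an edge, with a 3.3-fold higher number from compound 2 to compound 4 (0.52 log units; beyond the scatter) for this change, and among these four compounds acetyl stands apart as the only group without an amide hydrogen.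

A plain amino group, or a reversed amide ending in 3,4-difluorophenyl, would help to separate the part played by the amide hydrogen from that of the rest of the group. No measurement offered here explains these steps.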